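Chloro in place of phenoxy: working notes on compound 3

This account rests on a few compounds, and the source may have more. Where it says the series, first, only, none or still open, it means among the compounds named here.

In a functional assay on A549 cells (Homo sapiens) for inhibition, read by CellTiter-Glo, with a stated time of 48 h, in the presence of a further agent that is not named here (on this read-out higher numbers stand for weaker inhibition of growth and lower numbers for stronger inhibition of growth), compound 1 (`CS(=O)(=O)Nc1ccccc1Nc1nc(Nc2ccc(C(=O)OCc3ccccc3)cc2)ncc1F`) gives > 50000 nM as a limit and not a number. Going by the values given here, compound 2 (`CS(=O)(=O)Nc1ccccc1Nc1nc(Nc2ccc(Oc3ccccc3)cc2)ncc1F`) gives 26900 nM as the only number so far. Compound 3 (`CS(=O)(=O)Nc1ccccc1Nc1nc(Nc2ccc(Cl)cc2)ncc1F`) carries chloro in place of phenoxy on an aromatic carbon. Among the compounds with values here, the one measured step at this carbon (an at least 1.8-fold lower number from compound 1 to compound 2 (0.26 log units; that floor lies within the scatter)) starts from a limit (the limit of > 50000 nM in this assay, at which 1 of the 2 values shown sits) and so sets no size for a further change. The expected step (a 1.1-fold lower number from compound 2 to compound 3 (0.03 log units; within the scatter)) is estimated to stay within the scatter in this assay with no direction favoured. For compound 3 the estimate is 25000 nM with an expected range from 9000 nM to 50000 nM on this read-out.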

Compound 3, concentration for 50% growth inhibition: > 50000 nM
Compound 3: only a limit was reported; the forecaster's own chance of this, stated with the estimate: 30%; middle value at least 2.0-fold (0.30 log units) from the limit.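

Chloro in place of phenoxy gives an at least 1.8-fold higher number from compound 2 to compound 3 (0.26 log units; that floor lies within the scatter), so replacing phenoxy with a single chlorine atom brings no lower number at this carbon in this assay. Phenoxy remains the only group shown here that yields a number rather than a limit. The step from compound 1 to compound 3 cannot be read, and the read-out is now crowded at its ceiling: the limit of > 50000 nM in this assay, at which 2 of the 3 values shown sit.

Still open, from the compounds shown here alone, is whether an amine or a carboxylic acid on this carbon would give a number beyond the scatter from that of compound 2.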